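Variation at the benzyloxy aryl: estimating compound 4

This account rests on a few compounds, and the source may have more. Where it says the series, first, only, none or still open, it means among the compounds named here.

Measured compounds:
compound 1 `Cc1ccc(NC(=S)NC(=O)c2ccc(OCc3cccc(C(F)(F)F)c3)cc2)cc1-c1nc2ccccc2[nH]1` gives 15400 nM in a functional assay on SW-620 cells (Homo sapiens) for inhibition, read by MTT assay, with a stated time of 48 h; on this read-out lower numbers stand for stronger inhibition and higher numbers for weaker inhibition
compound 2 `Cc1ccc(NC(=S)NC(=O)c2ccc(OCc3ccccc3F)cc2)cc1-c1nc2ccccc2[nH]1` gives 6440 nM in this assay
compound 3 `Cc1ccc(COc2ccc(C(=O)NC(=S)Nc3ccc(C)c(-c4nc5ccccc5[nH]4)c3)cc2)cc1` gives 60900 nM in this assay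

Compound 3 stands highest of the three in this assay; the step of a 4.0-fold higher number from compound 1 to compound 3 (0.60 log units; beyond the scatter) and the step of a 9.5-fold higher number from compound 2 to compound 3 (0.98 log units; beyond the scatter) both lie beyond the scatter, so compound 3 is the weakest of the measured set. The step of a 2.4-fold lower number from compound 1 to compound 2 (0.38 log units; beyond the scatter) shows that the two substituted aryls on the saturated chain carbon bound to an oxygen on an aromatic ring also differ from each other.

Compound 4 `Cc1ccc(NC(=S)NC(=O)c2ccc(OCc3ccc(Cl)c(Cl)c3)cc2)cc1-c1nc2ccccc2[nH]1` is not yet measured. It differs from compound 3 by 3,4-dichlorophenyl in place of 4-methylphenyl on a saturated chain carbon bound to an oxygen on an aromatic ring. Going by the values given here, the steps that bear on this change are those that exchange the aryl at the same place: both 3-(trifluoromethyl)phenyl and 2-fluorophenyl gave lower numbers than 4-methylphenyl, as the steps to compound 3 show. Among the compounds with values here, no step with a dichloro aryl is available, so the size is uncertain, but the direction from compound 3 is expected to be downward, beyond the scatter. The expected step is a 6.8-fold lower number from compound 3 to compound 4 (0.83 log units; beyond the scatter), and compound 4 is estimated at 9000 nM, within 3000 nM to 30000 nM.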

Compound 4, half-maximal inhibitory concentration: 30700 nM
Compound 4: the middle estimate sits 3.4-fold (0.53 log units) below what was measured; the whole stated range lies below it.
By their numbers in this assay, from the lowest: compound 2; then compounds 1, 4 and 3 (each within the scatter of the next, the first and the last beyond it).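

In this assay the exchange of 4-methylphenyl for 3,4-dichlorophenyl gives a step within the scatter (a 2.0-fold lower number from compound 3 to compound 4 (0.30 log units; within the scatter)), and the exchange of 3-(trifluoromethyl)phenyl for 3,4-dichlorophenyl does the same (a 2.0-fold higher number from compound 1 to compound 4 (0.30 log units; within the scatter)), so at this position the new aryl cannot be told apart from either of those two aryls, even though those two differ from each other beyond the scatter. The 3,4-dichlorophenyl does separate from 2-fluorophenyl (a 4.8-fold higher number from compound 2 to compound 4 (0.68 log units; beyond the scatter)), which leaves compound 2 apart from the other three, with every one of its steps beyond the scatter, as the strongest of the four. Leaving 4-methylphenyl therefore does not by itself bring a step beyond the scatter: compounds 1 and 2 had suggested that pattern, and compound 4 goes against it.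

No measurement given here bears on the reason for these differences. Open, on these data alone, is whether an unsubstituted phenyl, a pyridine ring, or an aryl carrying an amine or a carboxylic acid on the saturated chain carbon bound to an oxygen on an aromatic ring would fall with compound 2 or with compounds 1, 3 and 4.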